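The source may report more compounds than this note shows. Statements on the series, on what has been measured and on what is new or still open speak of the compounds shown alone.

Working notes on the series, read in a functional assay on KB cells (Homo sapiens) for inhibition (a higher number here means a weaker inhibitor, a lower number a stronger inhibitor), for the shared core of compound 1 `Cc1ccc(Cn2c(Br)nc3cc(Cl)c(Cl)cc32)cc1` and its close relatives. Compound 1 gives > 100000 nM as a limit of the assay, not a number. Compound 2 `FC(F)(F)c1ccc(Cn2c(Br)nc3cc(Cl)c(Cl)cc32)cc1` gives > 100000 nM as a limit too, so it has no readable place on the scale. The evidence so far is the limit of > 100000 nM in this assay, at which 2 of the 2 values shown sit, and nothing firmer.

Next in line is compound 3 `O=[N+]([O-])c1ccc(Cn2c(Br)nc3cc(Cl)c(Cl)cc32)cc1` with nitro in place of trifluoromethyl on an aromatic carbon, para to a large group, counted as nitro in place of trifluoromethyl on an aromatic carbon for the whole swap. Within the data shown here, only one measured step bears on this change, a step that the two limits leave unreadable from compound 1 to compound 2 and it offers neither a size nor a direction. Nothing measured therefore points to a move beyond the scatter in this assay so none is expected, and another limit is the likeliest report. The estimate is a number no higher from compound 2 to compound 3 (the limit leaves the size open) with no clear direction expected. For compound 3 the estimated value is 100000 nM with an expected range from 30000 nM to 200000 nM as the working bracket.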

Compound 3, half-maximal inhibitory concentration: 40000 nM
Compound 3: middle estimate off by 2.5-fold (0.40 log units), on the high side, within the range that was stated.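

Nitro in place of trifluoromethyl, on an aromatic carbon para to a large group, brings the series onto the readable scale of this assay, with an at least 2.5-fold lower number from compound 2 to compound 3 (0.39 log units; beyond the scatter). The change from methyl at the same place reads the same way, with an at least 2.5-fold lower number from compound 1 to compound 3 (0.39 log units; beyond the scatter), so this position does respond to the group it carries, which the earlier pair could not show, as the step between its two members cannot be read. Both readable steps start from a limit and so give only a least size, and the limit still holds most of the values shown: the limit of > 100000 nM in this assay, at which 2 of the 3 values shown sit.

Going by these compounds, whether this step belongs to nitro alone, or whether a nitrile, an amine or a carboxylic acid on the same aromatic carbon would give a readable value as well, stays open. Also open, on these data alone, is whether the nitro step holds when the shared core changes elsewhere, for instance with an amine in place of the bromine, or when a longer chain replaces the link to the aromatic ring that carries the nitro group.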